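Anilide series in BJ cell inhibition: notes toward compound 3

A few compounds are considered here, and "the series" means these few. Any claim that something is new, unique, unknown or untested is made for them only; others in the source may bear on it.

compound 1 `O=C(Nc1ccc(Cl)cc1)c1cc([N+](=O)[O-])ccc1Cl`: > 25000 nM
compound 2 `CN(C)CCC(=O)Nc1cccc(-c2nc3ccccc3s2)c1`: > 25000 nM

In an ADME assay on BJ cells (Homo sapiens) for inhibition, with a stated time of 72 h (on this read-out lower numbers stand for an effect already at smaller amounts and higher numbers for an effect only at larger amounts of compound), compound 1 gives > 25000 nM, a limit of the assay and not a number. In this assay compound 2 gives > 25000 nM, likewise only a limit. Compound 2 thus sits at the limit of > 25000 nM in this assay, at which 2 of the 2 values shown sit, with nothing to set it apart from compound 1.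

Compound 3 `O=C(Nc1cccc(-c2nc3ccccc3s2)c1)c1ccc(Cl)nc1Cl` differs from compound 2 by 2,6-dichloropyridin-3-yl in place of 2-(dimethylamino)ethyl on a carbonyl carbon. For the measured compounds named here, no step between measured compounds is available, so the expected step from compound 2 to compound 3 in this assay is an at least 1.2-fold lower number from compound 2 to compound 3 (0.09 log units; that floor lies within the scatter), most probably none beyond the scatter. Compound 3 is accordingly expected to give 20000 nM in this assay, between 4000 nM and 60000 nM.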

Compound 3, half-maximal effective concentration: > 25000 nM
Compound 3: no number, only a limit; the forecaster's own chance of this, stated with the estimate: 60%; middle value at least 1.2-fold (0.09 log units) from the limit.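

No step can be read from compound 2 to compound 3, since both give only a limit in this assay: the limit of > 25000 nM in this assay, at which 3 of the 3 values shown sit.

The compounds shown leave open what number any of them would give in this assay, and whether the group on the carbonyl carbon matters there.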